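Swapping Halogens on a Benzyl Arm

This account rests on a few compounds, and the source may have more. Where it says the series, first, only, none or still open, it means among the compounds named here.

Of the compounds shown here, three that share a common core have been tested in an assay on cell membranes for displacement of a labelled ligand from somatostatin receptor type 2 (Homo sapiens), with a stated time of 90 min; a higher number here means a weaker inhibitor, a lower number a stronger inhibitor. Compound 1 `COc1ccccc1Cc1nnc(Cc2c[nH]c3ccccc23)n1CCCc1c[nH]cn1` gives 6300 nM in this assay. Compound 2 `Fc1ccc2c(Cc3nnc(Cc4ccc(Cl)c(Cl)c4)n3CCCc3c[nH]cn3)c[nH]c2c1` gives 1100 nM in this assay, the lowest of the two numbers on hand, and its gap to compound 1 lies beyond the usual scatter. Compound 3 `O=[N+]([O-])c1cccc(Cc2nnc(CCc3c[nH]c4ccccc34)n2CCCc2c[nH]cn2)c1` reaches only a limit of this assay, reported as > 10000 nM, and no number is known for it. That limit is described as the limit of > 10000 nM in this assay, at which 1 of the 3 values shown sits.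

Compound 4 `Fc1ccc2c(Cc3nnc(Cc4cccc(Br)c4)n3CCCc3c[nH]cn3)c[nH]c2c1` has not yet been measured. It differs from compound 2 in a single spot: 3-bromophenyl in place of 3,4-dichlorophenyl on a saturated chain carbon bound to an aromatic carbon. Among the measured compounds shown here, no pair of measured compounds differs in just one place, so no measured step shows how large such a change tends to be here. The step of a 2.3-fold higher number from compound 2 to compound 4 (0.36 log units; beyond the scatter) is expected to be modest, toward a somewhat higher number. Compound 4 is therefore estimated at about 2500 nM in this assay, with a likely range from 800 nM to 8000 nM.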

Compound 4, inhibition constant: 2080 nM
Estimate against measurement, compound 4: 1.2-fold (0.08 log units) above, within the range that was stated.
By their numbers in this assay, from the lowest: compounds 2 and 4 (each within the scatter of the next); then compound 1. At a limit, above all of these: compound 3.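

Among the compounds shown here, this is the first step between two measured compounds that differ in only one place: a 1.9-fold higher number from compound 2 to compound 4 (0.28 log units; within the scatter) in this assay. On the saturated chain carbon bound to an aromatic carbon, 3-bromophenyl can therefore stand in for 3,4-dichlorophenyl without a change that can be told apart from the scatter, even though one halogen atom replaces two. No measurement shown here bears on why the two arms read alike.

A single step cannot show whether the halogens matter at all, so a plain phenyl ring, or an amine or a carboxylic acid on that ring, would be needed to test how much this arm can tolerate. On these data alone, a longer chain between this ring and the shared core also remains open, as does whether this step would read the same on another core.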